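The source may hold more compounds than are shown below. What is called first, only, known or untested is meant among the compounds shown, and "the series" means these compounds.

The measured compounds:

Compound 1 `CCCCCCCCCCOc1cc(OCCCCCCCCCC)cc(OCCCCCCN(Cc2ccc(C(=O)OC)cc2)c2ccc(C(=O)OC)cc2)c1` — in an assay on isolated protein for binding affinity to P-selectin (Homo sapiens), read by ELISA, tested at 500 uM (on this read-out lower numbers stand for less inhibition and higher numbers for more inhibition at the one concentration tested (going by the name of the read-out)), compound 1 gives "not determined" (no result reported).
Compound 2 `CCCCCCCCCCOc1cc(OCCCCCCCCCC)cc(OCCCCCC(=O)N(c2ccc(C(=O)OC)cc2)c2ccc(C(=O)OC)c(C(=O)OC)c2)c1` — in this assay compound 2 gives 90%.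
Compound 3 `CCCCCCCCCCOc1cc(OCCCCCCCCCC)cc(OCCCCCC(=O)N(c2cccc(C(=O)O)c2)c2cccc(C(=O)O)c2)c1` — in this assay compound 3 gives 20%.

Compound 3 stands lowest of the two numbers in hand. Its nearest neighbour is compound 2, whose reading is higher, a gap beyond the scatter; compound 1 adds nothing to the comparison, since no number was reported for it. Among the measured compounds shown here, no two measured compounds differ in a single place, so no single step in this assay is known, and the distance from compound 3 to compound 2 reflects several changes at once.

Compound 4 `CCCCCCCCCCOc1cc(OCCCCCCCCCC)cc(OCCCCCC(=O)N(c2cccc(C(=O)O)c2)c2ccc(C(=O)O)c(C(=O)O)c2)c1` is the unmeasured compound. It differs from compound 3 in one place: carboxy in place of hydrogen on an aromatic carbon. Compound 4 thus carries a 3,4-dicarboxyphenyl group where compound 3 carries a 3-carboxyphenyl group, a pattern that compound 2 shows in its ester form.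

For the measured compounds named here, with no single step to lean on, the expected step from compound 3 to compound 4 in this assay is a modest rise, a number 15 percentage points higher from compound 3 to compound 4 (beyond the scatter), not far beyond the scatter. Compound 4 is accordingly estimated at 35%, within a range from 10% to 65%.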

Compound 4, a percentage reported as inhibition, at one concentration (the size of the read-out at that concentration, not a potency): 102%
Compound 4: middle estimate off by 67 percentage points, on the low side, outside the stated range (above it).
By their numbers in this assay, from the lowest: compound 3; then compound 2; then compound 4.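

In this assay the change of carboxy in place of hydrogen on an aromatic carbon gives the first single-place step known for this series, and that step is a number 82 percentage points higher from compound 3 to compound 4 (beyond the scatter). The new carboxy stands ortho to a carboxy group and para to a large group, turning one 3-carboxyphenyl into 3,4-dicarboxyphenyl while the other 3-carboxyphenyl and the rest of the shared core stay as they are, so this one aromatic position can by itself shift the reading far beyond the scatter. Among the compounds shown here, nothing available accounts for the size of this step, and the single pair gives no reason for it.

The compounds shown leave open whether the step depends on a carboxylic acid at this position, or whether a hydroxy group, an amine or a sulfonic acid placed there would shift the reading in the same way. They also leave open whether the same carboxy added to the other 3-carboxyphenyl would give a step of similar size.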